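Para substituent swap on the aryl amine of compound 1

The source may hold more compounds than are shown below. What is called first, only, known or untested is meant among the compounds shown, and "the series" means these compounds.

Compound 1 `C=C1[C@@H](OC(C)=O)C[C@@H]2[C@](C)(CO[Si](C)(C)C(C)(C)C)[C@H](OC(C)=O)CC[C@@]2(C)[C@@H]1C[C@@H](Nc1ccc(Br)cc1)C1=CCOC1=O` gives 4150 nM in a functional assay on A549 cells (Homo sapiens) for cytotoxicity, read by sulforhodamine B assay (a lower number here means a stronger inhibitor, a higher number a weaker inhibitor), the lowest number among the three measured compounds. Compound 3 `C=C1[C@@H](OC(C)=O)C[C@@H]2[C@](C)(CO[Si](C)(C)C(C)(C)C)[C@H](OC(C)=O)CC[C@@]2(C)[C@@H]1C/C=C1/C(=O)OC[C@H]1OC(C)=O` gives 4640 nM, which lies within the scatter of compound 1, so the two cannot be ordered. Compound 2 `C=C1[C@@H](OC(C)=O)C[C@@H]2[C@](C)(COC=O)[C@H](OC(C)=O)CC[C@@]2(C)[C@@H]1C/C=C1/C(=O)OC[C@H]1OC(C)=O` gives 19000 nM, the highest number of the three. Among the compounds with values here, the one single-point step in the set, a 4.1-fold lower number from compound 2 to compound 3 (0.61 log units; beyond the scatter), concerns the group on an oxygen on a saturated carbon of the shared core and does not touch the aryl amine side chain.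

Compound 4 `C=C1[C@@H](OC(C)=O)C[C@@H]2[C@](C)(CO[Si](C)(C)C(C)(C)C)[C@H](OC(C)=O)CC[C@@]2(C)[C@@H]1C[C@@H](Nc1ccc(OC)cc1)C1=CCOC1=O` differs from compound 1 by methoxy in place of bromo on an aromatic carbon. Within the data shown here, no measured pair changes the group on this six-membered aromatic ring, so nothing here speaks directly to the size or direction of the step. With the silyl group and the core held as in compound 1, the number for compound 4 is expected to stay near that of compound 1, giving an estimated step of a 1.2-fold higher number from compound 1 to compound 4 (0.08 log units; within the scatter). Compound 4 is therefore estimated at 5000 nM, with a range from 1500 nM to 16000 nM.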

Compound 4, half-maximal inhibitory concentration: 4810 nM
For compound 4 the middle estimate is 1.0-fold (0.02 log units) above the measured one; the measured number falls inside the stated range.
By their numbers in this assay, from the lowest: compounds 1, 3 and 4 (each within the scatter of the next); then compound 2.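

Within the data shown here, the first pair to change the group on the six-membered aromatic ring reads as a 1.2-fold higher number from compound 1 to compound 4 (0.06 log units; within the scatter) in this assay with methoxy in place of bromo, so the two groups cannot be told apart at this place, para to a large group. This holds for this one pair, with the silyl group and the shared core kept as they are, and it gives no trend across substituents on the ring. No separate measurement bears on this result.

Open, as far as these compounds go, is whether a different group at this place, such as an amine, a carboxylic acid or a longer chain, would also stay within the scatter of compound 1. Also open, from the compounds shown here alone, is whether the same swap would read alike on a core carrying a group other than the silyl group.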